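Swapping a hydroxypentyl chain for a fluorophenyl ring

This account rests on a few compounds, and the source may have more. Where it says the series, first, only, none or still open, it means among the compounds named here.

Of the compounds shown here, three sharing one core have been tested in an ADME assay on PANC-1 cells (Homo sapiens) for cytotoxicity, read by sulforhodamine B assay, with a stated time of 48 h, tested at 10 uM; a higher number here means more inhibition at the concentration tested (going by the name of the read-out), a lower number less inhibition. Compound 1, `COc1nc2ccc(Br)cc2cc1C(c1ccccc1)n1cc(-c2ccc(Br)cc2)nn1`, gives 10.4%. Compound 2, `COc1nc2ccc(Br)cc2cc1C(c1ccccc1)n1cc(-c2cccc(F)c2)nn1`, gives 15.5%. Compound 3, `COc1nc2ccc(Br)cc2cc1C(c1ccccc1)n1cc(CCCCCO)nn1`, gives 19.6%. Compound 3 thus has the top number of the three, yet both gaps to the other two lie within the scatter: the step of a number 9.2 percentage points higher from compound 1 to compound 3 (within the scatter) and the step of a number 4.1 percentage points higher from compound 2 to compound 3 (within the scatter) are each too small to count as real change, as is the step of a number 5.1 percentage points higher from compound 1 to compound 2 (within the scatter).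

Compound 4 is `COc1nc2ccc(Br)cc2cc1C(c1ccccc1)n1cc(-c2ccc(F)cc2)nn1`. Its difference from compound 3 is 4-fluorophenyl in place of 5-hydroxypentyl on an aromatic carbon. For the measured compounds named here, the steps that bear on this are those where a ring replaced a chain or one ring replaced another, all within the scatter, so in this assay no step beyond the scatter is expected from compound 3 to compound 4, and the estimated step is a number 6.6 percentage points lower from compound 3 to compound 4 (within the scatter). For compound 4 the expected value is 13%, with a range from 3% to 25%.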

Compound 4, a percentage reported as inhibition, at one concentration (the size of the read-out at that concentration, not a potency): 14.9%
The estimate for compound 4 lay 1.9 percentage points below the measured number; low and high end bracket the measured number.
By their numbers in this assay, from the lowest: compounds 1, 4, 2 and 3 (each within the scatter of the next).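

In this assay, the triazole position accepts a large change of type without a step beyond the scatter: a number 4.7 percentage points lower from compound 3 to compound 4 (within the scatter) comes from replacing a ring-free chain bearing a hydrogen-bond donor with an aromatic ring that has none. Within the aryl series, moving the fluoro group gives a number 0.6 percentage points lower from compound 2 to compound 4 (within the scatter) and exchanging bromo for fluoro at the ring gives a number 4.5 percentage points higher from compound 1 to compound 4 (within the scatter) so neither the place nor the kind of halogen separates these compounds in this assay. Nothing measured here explains these small differences.

These four compounds therefore show no real difference at this position, and a single concentration says nothing about potency. Going by these compounds, whether an amine, a carboxylic acid or a longer chain there would give a step beyond the scatter remains open.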